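This account rests on a few compounds, and the source may have more. Where it says the series, first, only, none or still open, it means among the compounds named here.

Compound 1 `CN(C)CCCNc1nc2cc([N+](=O)[O-])ccc2nc1NCc1ccc(C(F)(F)F)cc1` — 5.66 ug/mL
Compound 2 `CN(C)CCCNc1nc2cc([N+](=O)[O-])ccc2nc1NCc1ccc(Cl)cc1` — 10.7 ug/mL

Among the measured compounds shown here, only two compounds have been measured in an ADME assay on HEK293 cells (Homo sapiens) for cytotoxicity, read by MTT assay, with a stated time of 24 h (on this read-out lower numbers stand for stronger inhibition and higher numbers for weaker inhibition), and compound 2 stands at one end of that pair: the step of a 1.9-fold higher number from compound 1 to compound 2 (0.28 log units; within the scatter) separates it from compound 1, the nearest and only other number, so the two are not meaningfully apart.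

Compound 3 `CN(C)CCCNc1nc2cc([N+](=O)[O-])ccc2nc1NCc1ccc(Cl)c(C(F)(F)F)c1` differs from compound 2 in one place: trifluoromethyl in place of hydrogen on an aromatic carbon. For the measured compounds named here, the one measured step that bears on this is the exchange between compound 1 and compound 2, where trifluoromethyl gave way to chloro at the same ring with a result inside the scatter, a 1.9-fold higher number from compound 1 to compound 2 (0.28 log units; within the scatter). Compound 3 now carries both groups on that ring. Since the swap of those two groups moved the number so little, adding the trifluoromethyl back is expected to produce no step beyond the scatter, a 1.4-fold lower number from compound 2 to compound 3 (0.15 log units; within the scatter), leaning if anything toward the number of compound 1 because of 5.66 ug/mL. Compound 3 is therefore estimated at 7.5 ug/mL, within 3 ug/mL to 18 ug/mL.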

Compound 3, half-maximal inhibitory concentration: 3.26 ug/mL
Beside the measured number, compound 3's estimate is 2.3-fold (0.36 log units) above it, and the stated range covers the measured number.
By their numbers in this assay, from the lowest: compounds 3, 1 and 2 (each within the scatter of the next, the first and the last beyond it).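

In this assay, trifluoromethyl on the ring carbon ortho to the chloro group moves the number modestly but beyond the scatter, a 3.3-fold lower number from compound 2 to compound 3 (0.52 log units; beyond the scatter), so this position can register a change on the 4-chlorophenyl ring. Replacing 4-(trifluoromethyl)phenyl with 4-chloro-3-(trifluoromethyl)phenyl, by contrast, leaves the result within the scatter, a 1.7-fold lower number from compound 1 to compound 3 (0.24 log units; within the scatter), so the two rings cannot be told apart in this assay. Nothing available explains why the added group shifts the number from the 4-chlorophenyl ring.

The compounds shown leave open whether this step is particular to trifluoromethyl or would also appear with a methyl, a methoxy or a nitrile at the same carbon. Going by these compounds, it is also open whether trifluoromethyl at this carbon would give a similar number with no chloro group on the ring.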